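A few compounds are considered here, and "the series" means these few. Any claim that something is new, unique, unknown or untested is made for them only; others in the source may bear on it.

Working notes on the series. Compound 1 (`O=[N+]([O-])c1ccccc1-c1nc2ccccc2[nH]1`), compound 2 (`O=[N+]([O-])c1ccc(-c2nc3ccccc3[nH]2)c([N+](=O)[O-])c1`) and compound 3 (`Oc1ccc(-c2nc3cc(C(F)(F)F)ccc3[nH]2)cc1`) have been measured in an ADME assay on MT4 cells (Homo sapiens) for cytotoxicity, read by MTT assay, with a stated time of 96 h; a higher number here means that more compound is tolerated, a lower number that less compound is tolerated. Compound 2 gives 7000 nM, the lowest of the three numbers, while compound 3 gives 17000 nM and compound 1 gives 60000 nM.

Compound 4 (`O=[N+]([O-])c1ccc(-c2nc3cc(C(F)(F)F)ccc3[nH]2)c([N+](=O)[O-])c1`) is the next to be read, and it departs from compound 2 by one change: trifluoromethyl in place of hydrogen on an aromatic carbon. Going by the values given here, the only measured single-place step is an 8.6-fold lower number from compound 1 to compound 2 (0.93 log units; beyond the scatter), which concerns a nitro group, so it bears on the new change only as a rough guide to how large a step can be. Compound 3 already carries trifluoromethyl and shows 17000 nM, but no partner without that group has been measured, so no direct size for this change exists.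

A small move towards a lower number is therefore expected in this assay, possibly none beyond the scatter. The expected change is a 1.4-fold lower number from compound 2 to compound 4 (0.15 log units; within the scatter). For compound 4 the estimated value is 5000 nM, with an expected range of 1800 nM to 14000 nM.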

Compound 4, half-maximal cytotoxic concentration: 9000 nM
Compound 4: middle estimate off by 1.8-fold (0.26 log units), on the low side; measured number inside the range.
By their numbers in this assay, from the lowest: compounds 2, 4 and 3 (each within the scatter of the next, the first and the last beyond it); then compound 1.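

In this assay the step of trifluoromethyl in place of hydrogen gives a 1.3-fold higher number from compound 2 to compound 4 (0.11 log units; within the scatter) and so puts the first measured size on this change. Going by these compounds alone, on this aromatic carbon of the fused system, with the rest of compound 2 kept, the added group leaves the two compounds indistinguishable, whereas the only earlier step, an 8.6-fold lower number from compound 1 to compound 2 (0.93 log units; beyond the scatter), concerned a nitro group and lay beyond the scatter. No measurement at hand gives a reason for this result.

Whether the same change reads alike with other groups on the other ring stays open, since compound 3 has no partner lacking trifluoromethyl among the compounds shown. Also open, as far as these compounds go, is whether an amine, a carboxylic acid or a longer chain at this position would shift the number beyond the scatter.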